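The source may hold more compounds than are shown below. What is called first, only, known or untested is meant among the compounds shown, and "the series" means these compounds.

Of the compounds shown here, three of a shared core have been measured in a functional assay on SF-268 cells (Homo sapiens) for cytotoxicity, read by sulforhodamine B assay, with a stated time of 48 h, tested at 10 uM; on this read-out higher numbers stand for a weaker effect at the one concentration tested and lower numbers for a stronger effect. Compound 1 `COc1ccc(-c2cc(/C=C/C(=O)c3cc(OC)c(OC)c(OC)c3)[nH]n2)cc1OC` gives -56%. Compound 2 `COc1ccc(C(=O)/C=C/c2cc(-c3cc(OC)c(OC)c(OC)c3)n[nH]2)cc1` gives -35%, and compound 3 `COc1ccc(C(=O)/C=C/c2cc(-c3cc(OC)c(OC)c(OC)c3)n[nH]2)cc1OC` gives -60%. Compound 3 therefore stands with the lowest number of the three: its value lies within the scatter of that of compound 1, while the step of a number 25 percentage points lower from compound 2 to compound 3 (beyond the scatter) lies beyond the scatter.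

The unmeasured compound 4 `COc1cc(C(=O)/C=C/c2cc(-c3cc(OC)c(OC)c(OC)c3)n[nH]2)cc(OC)c1OC` differs from compound 3 in one place: methoxy in place of hydrogen on an aromatic carbon. For the measured compounds named here, the one measured step of the same kind, a number 25 percentage points lower from compound 2 to compound 3 (beyond the scatter), was modest and lowered the number. That step, however, placed a methoxy group where compound 2 had none, whereas in compound 4 the new methoxy enters a ring that already carries two methoxy groups, as described above. Going by the values given here, no measured step matches this exactly. Compound 4 is thus expected to sit near compound 3 or somewhat lower, with a step of a number 6 percentage points lower from compound 3 to compound 4 (within the scatter) that may not exceed the scatter. The estimate for compound 4 is -66%, with a range from -88% to -40%.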

Compound 4, a percentage reported as activity, at one concentration (the size of the read-out at that concentration, not a potency): -45%
Beside the measured number, compound 4's estimate is 21 percentage points below it; measured number inside the range.
By their numbers in this assay, from the lowest: compounds 3 and 1 (each within the scatter of the next); then compounds 4 and 2 (each within the scatter of the next).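

In this assay, methoxy in place of hydrogen on an aromatic carbon does not keep lowering the number once the ring already carries two methoxy groups: the result is a number 15 percentage points higher from compound 3 to compound 4 (beyond the scatter). The same kind of change made on the core of compound 1 also raises the number, giving a number 11 percentage points higher from compound 1 to compound 4 (beyond the scatter). A methoxy in place of hydrogen therefore has no single direction among these compounds, and compound 2 and compound 3 go against any rule that more methoxy groups raise the number: the same change on two cores in this assay, a number 25 percentage points lower (beyond the scatter) from compound 2 to compound 3 and a number 11 percentage points higher (beyond the scatter) from compound 1 to compound 4, 36 percentage points apart, beyond the scatter of two such steps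

As far as these compounds go, what a hydroxyl group or an amine would give in place of the new methoxy remains open. Also open, from the compounds shown here alone, is whether these steps would keep their direction at other concentrations, as each read-out comes from a single concentration.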